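The compounds below may be only part of what the source reports. "The series", "measured", "known", "first", "only" and "open" are said of these compounds alone.

Compound 1 `CCOC(=O)CN(C)C(=O)c1ccc(C(CC)(CC)c2ccc(OCC(O)C(C)(C)C)c(C)c2)n1CC` gives 210 nM in an assay on HL-60 cells for agonist activity at vitamin D3 receptor (Homo sapiens), read by microscopy, with a stated time of 96 h; a lower number here means that less compound is needed, a higher number that more compound is needed for the effect.
Compound 2 `CCn1c(C(=O)NCCN)ccc1C(CC)(CC)c1ccc(OCC(O)C(C)(C)C)c(C)c1` gives 10 nM in this assay.
Compound 3 `CCn1c(C(=O)N(C)CCC#N)ccc1C(CC)(CC)c1ccc(OCC(O)C(C)(C)C)c(C)c1` gives 1960 nM in this assay.

Compound 3 stands highest of the three, needing the most compound; the nearest is compound 1 with a 9.3-fold higher number from compound 1 to compound 3 (0.97 log units; beyond the scatter) and the furthest is compound 2 with a 200-fold higher number from compound 2 to compound 3 (2.29 log units; beyond the scatter). Compound 4 `C#CCCOC(=O)c1ccc(C(CC)(CC)c2ccc(OCC(O)C(C)(C)C)c(C)c2)n1CC` differs from compound 3 by (but-3-yn-1-yl)oxy in place of (2-cyanoethyl)(methyl)amino on a carbonyl carbon. Among the measured compounds shown here, no measured step swaps the amide-type nitrogen for an oxygen at this carbonyl, so the nearest guides are the changes at this position already seen, a 9.3-fold higher number from compound 1 to compound 3 (0.97 log units; beyond the scatter) and a 200-fold higher number from compound 2 to compound 3 (2.29 log units; beyond the scatter), which show that this position moves the number widely. A modest lower number is expected in this assay, with a 3.9-fold lower number from compound 3 to compound 4 (0.59 log units; beyond the scatter). Compound 4 is estimated at 500 nM, within 100 nM to 3000 nM.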

Compound 4, half-maximal effective concentration: 1030 nM
Estimate against measurement, compound 4: 2.1-fold (0.31 log units) below; measured number inside the range.
By their numbers in this assay, from the lowest: compound 2; then compound 1; then compounds 4 and 3 (each within the scatter of the next).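

Swapping the (2-cyanoethyl)(methyl)amino group for (but-3-yn-1-yl)oxy on this carbonyl carbon makes no clear difference in this assay (a 1.9-fold lower number from compound 3 to compound 4 (0.28 log units; within the scatter)), so the ester of compound 4 and the amide of compound 3 cannot be told apart here. Compound 2 remains well separated (a 100-fold higher number from compound 2 to compound 4 (2.01 log units; beyond the scatter)), and compound 1 also differs from the ester (a 4.9-fold higher number from compound 1 to compound 4 (0.69 log units; beyond the scatter)), so amide compounds at this carbonyl span a wide range. Nothing shown explains these differences.

From the compounds shown here alone, a carboxylic acid or a 3-aminopropyl amide at this carbonyl remains unknown. It is therefore open whether the end amine of compound 2 or its amide hydrogen goes with its low number.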